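The source may hold more compounds than are shown below. What is called first, only, known or untested is meant among the compounds shown, and "the series" means these compounds.

Measured compounds:
- compound 1 `COCCNC(=O)CNc1ncc2c(Br)nn(-c3ccc4ncccc4c3)c2n1` — in an assay on SK-OV-3 cells for inhibition of eIF-2-alpha kinase GCN2 (Homo sapiens) (on this read-out higher numbers stand for weaker inhibition and lower numbers for stronger inhibition), compound 1 is entered as "nd" (no result reported) (no number reported)
- compound 2 `COCc1noc([C@@H]2CC[C@@H](Nc3ncc4c(Br)nn(-c5ccc6ncccc6c5)c4n3)C2)n1` — in this assay compound 2 is entered as "nd" (no result reported) (no number reported)
- compound 3 `CS(=O)(=O)N1CC[C@@H](Nc2ncc3c(Br)nn(-c4ccc5ncccc5c4)c3n2)C1` — in this assay compound 3 gives 378 nM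

Among the compounds with values here, compound 3 thus holds the only numerical result in the set; the two further entries carry no result, so compound 3 cannot be placed relative to them, and no step between measured compounds exists from which to read how a change at this position moves the read-out.

Compound 4 `CNC(=O)[C@@H]1CC[C@@H](Nc2ncc3c(Br)nn(-c4ccc5ncccc5c4)c3n2)C1` differs from compound 3 in one place: a group of 9 heavy atoms (7 carbon, 1 nitrogen, 1 oxygen; one five-membered non-aromatic ring of carbon only) in place of a group of 9 heavy atoms (5 carbon, 1 nitrogen, 2 oxygen, 1 sulfur; one five-membered non-aromatic ring with 1 hetero atom), on a nitrogen on an aromatic ring. The shared core and the point of attachment are unchanged.

Within the data shown here, with no measured step of this kind available, there is no basis for expecting a shift beyond the scatter in this assay; the step is expected to come to a 1.1-fold higher number from compound 3 to compound 4 (0.02 log units; within the scatter), within the usual scatter, with the range kept wide to reflect the missing precedent. Compound 4 is accordingly estimated at 400 nM in this assay, with a range from 120 nM to 1500 nM.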

Compound 4, half-maximal inhibitory concentration: 25 nM
Estimate against measurement, compound 4: 16-fold (1.20 log units) above; the measured number lies below the stated range.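

In this assay, this position, on a nitrogen on an aromatic ring, proves sensitive to the group it carries: replacing 1-(methylsulfonyl)pyrrolidin-3-yl with the carbon-only five-membered ring bearing a methyl amide gives a 15-fold lower number from compound 3 to compound 4 (1.18 log units; beyond the scatter), a step that the earlier entries could not reveal. Both groups have 9 heavy atoms, so for this pair, heavy-atom count alone does not set the read-out, while the entering group has 1 hydrogen-bond donor against 0 and 2 defined stereocentres against 1. No measurement shown accounts for the step.

The ring and its substituent change together, leaving open which one carries the step; an acetyl group on the pyrrolidine nitrogen, or a carboxylic acid on the carbon-only ring, would help separate them. Compound 1 and compound 2 have no numerical result, so their side chains remain unplaced against either value.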